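A Chloro Swap on a Weak Compound

The source may hold more compounds than are shown below. What is called first, only, known or untested is meant among the compounds shown, and "the series" means these compounds.

In a functional assay on MDA-MB-231 cells (Homo sapiens) for inhibition, read by MTT assay, with a stated time of 72 h (a lower number here means a stronger inhibitor, a higher number a weaker inhibitor), compound 1 `CC(C)(C)n1cc2c(n1)C(=O)CC1(CCN(C(=O)c3cc(-c4ccccc4)nc4ccccc34)CC1)O2` reads > 10000 nM, which is a limit of the assay. Compound 2 `CC(C)(C)n1cc2c(n1)C(=O)CC1(CCN(C(=O)c3cc(-c4ccc(N)cc4)nc4ccccc34)CC1)O2` gives 4960 nM. Compound 3 `CN1CCN(c2cc(C(=O)N3CCC4(CC3)CC(=O)c3nn(C(C)(C)C)cc3O4)c3ccccc3n2)CC1` gives 8130 nM, a value within the scatter of compound 2. Compound 4 `CC(C)(C)n1cc2c(n1)C(=O)CC1(CCN(C(=O)c3cc(Cl)nc4ccccc34)CC1)O2` carries chloro in place of 4-methylpiperazin-1-yl on an aromatic carbon, next to the ring nitrogen: chloro in place of 4-methylpiperazin-1-yl on an aromatic carbon. Two measured steps change the group on this same carbon. One is a 1.6-fold higher number from compound 2 to compound 3 (0.21 log units; within the scatter). The other, which rests on a limit, is an at least 1.2-fold lower number from compound 1 to compound 3 (0.08 log units; that floor lies within the scatter). Neither shows a change beyond the scatter, so none is expected here, and the estimated step is a 1.1-fold higher number from compound 3 to compound 4 (0.04 log units; within the scatter). Compound 4 is expected at 9000 nM, within an estimated range of 4000 nM to 20000 nM.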

Compound 4, half-maximal inhibitory concentration: 9220 nM
For compound 4 the middle estimate is 1.0-fold (0.01 log units) below the measured one, within the range that was stated.
By their numbers in this assay, from the lowest: compounds 2, 3 and 4 (each within the scatter of the next). At a limit, above all of these: compound 1.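

In this assay, a single chlorine on this carbon replaces a ring-bearing group of seven heavy atoms with little effect (a 1.1-fold higher number from compound 3 to compound 4 (0.05 log units; within the scatter)), so group size alone does not separate these compounds. Chloro also stays within the scatter of 4-aminophenyl (a 1.9-fold higher number from compound 2 to compound 4 (0.27 log units; within the scatter)). The comparison with phenyl (an at least 1.0-fold lower number from compound 1 to compound 4 (0.03 log units; that floor lies within the scatter)) cannot show how large that step really is, as compound 1 gives only a limit: the limit of > 10000 nM in this assay, at which 1 of the 4 values shown sits.

From the compounds shown here alone, whether a carboxylic acid or a longer amine chain on this carbon would move the number beyond the scatter remains open.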